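The source may report more compounds than this note shows. Statements on the series, on what has been measured and on what is new or still open speak of the compounds shown alone.

Measured compounds:
compound 1 `O=C(Nc1ccc(S(=O)(=O)N2CCOCC2)c2ccccc12)c1ccccc1` — 7750 nM
compound 2 `CCC(=O)N1CCC(NS(=O)(=O)c2ccc(NC(=O)c3ccccc3C)c3ccccc23)CC1` — 2.5 nM
compound 3 `Cc1ccccc1C(=O)Nc1ccc(S(=O)(=O)NC2CCN(C(=O)C3CCCC3)CC2)c2ccccc12` — 9.1 nM

In an assay on L1.2 cells for binding affinity to C-C chemokine receptor type 8 (Homo sapiens) (on this read-out lower numbers stand for stronger inhibition and higher numbers for weaker inhibition), compound 3 stands second highest of the three numbers; its nearest neighbour is compound 2, and compound 1 lies far from it. Compound 4 `Cc1ccccc1C(=O)Nc1ccc(S(=O)(=O)NC2CCN(C(=O)CN)CC2)c2ccccc12` differs from compound 3 by one change: aminomethyl in place of cyclopentyl on a carbonyl carbon. Among the measured compounds shown here, only one measured step concerns this carbonyl carbon, a 3.6-fold higher number from compound 2 to compound 3 (0.56 log units; beyond the scatter), where a larger group gave the higher number. Compound 4 returns to a small group, so a step back toward the number of compound 2 is expected, while the amine carries nothing in these data to judge by. Compound 4 is therefore expected at 5 nM, between 1.5 nM and 20 nM, that is a 1.8-fold lower number from compound 3 to compound 4 (0.26 log units; within the scatter).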

Compound 4, inhibition constant: 4.1 nM
Estimate against measurement, compound 4: 1.2-fold (0.09 log units) above, and the stated range covers the measured number.
By their numbers in this assay, from the lowest: compounds 2 and 4 (each within the scatter of the next); then compound 3; then compound 1.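

Aminomethyl on this carbonyl carbon keeps the number low, and the cyclopentyl ring is not needed to reach it: the change brings a 2.2-fold lower number from compound 3 to compound 4 (0.35 log units; beyond the scatter). Amino in place of methyl on the saturated chain carbon gives a 1.6-fold higher number from compound 2 to compound 4 (0.21 log units; within the scatter), so on these numbers the amine and the methyl cannot be told apart at this place. Nothing given here explains either step. From the compounds shown here alone, it remains open whether a longer chain ending in an amine, or a carboxylic acid at this place, would keep the number this low.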